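Notes on aryl substituent changes in compounds 1 to 4

This account rests on a few compounds, and the source may have more. Where it says the series, first, only, none or still open, it means among the compounds named here.

Measured so far:
compound 1 `CC(c1ccc(-c2ccccc2)c(F)c1)c1nnc2n1N=C(c1ccc(Cl)cc1Cl)CS2` — in a functional assay on Mahlavu cells (Homo sapiens) for inhibition, read by sulforhodamine B assay, with a stated time of 72 h (on this read-out lower numbers stand for stronger inhibition and higher numbers for weaker inhibition), compound 1 gives 6600 nM
compound 2 `CC(c1ccc(-c2ccccc2)c(F)c1)c1nnc2n1N=C(c1ccc(Cl)cc1)CS2` — compound 2 gives 6100 nM
compound 3 `CC(c1ccc(-c2ccccc2)c(F)c1)c1nnc2n1N=C(c1ccc(F)cc1)CS2` — compound 3 gives 7400 nM

Within the data shown here, compound 3 carries the highest number of the three, but no step separates it from the others: a 1.1-fold higher number from compound 1 to compound 3 (0.05 log units; within the scatter) and a 1.2-fold higher number from compound 2 to compound 3 (0.08 log units; within the scatter). The step of a 1.1-fold lower number from compound 1 to compound 2 (0.03 log units; within the scatter) is equally small. Across these three compounds, changes to the substituents on the aryl ring attached to the carbon with a double bond to nitrogen have left the read-out essentially unchanged.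

Compound 4 `CC(c1ccc(-c2ccccc2)c(F)c1)c1nnc2n1N=C(c1ccc([N+](=O)[O-])cc1)CS2` differs from compound 3 by nitro in place of fluoro on an aromatic carbon. Among the measured compounds shown here, no measured pair covers a nitro group, so the only guide is the three steps above, each within the scatter, all of them exchanges on the same aryl ring. On that basis no step beyond the scatter is expected in this assay for compound 4, in either direction; the expected step is a 1.1-fold lower number from compound 3 to compound 4 (0.02 log units; within the scatter).

On these data alone, compound 4 is therefore estimated at 7000 nM, with a range from 3000 nM to 16000 nM, the width reflecting that a nitro group is untested.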

Compound 4, half-maximal inhibitory concentration: 9400 nM
For compound 4 the middle estimate is 1.3-fold (0.13 log units) below the measured one, within the range that was stated.
By their numbers in this assay, from the lowest: compounds 2, 1, 3 and 4 (each within the scatter of the next).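

In this assay the exchange of 4-fluorophenyl for 4-nitrophenyl gives a 1.3-fold higher number from compound 3 to compound 4 (0.10 log units; within the scatter) and so extends the flat picture on this aryl ring to a group of a different kind: nitro, with 3 heavy atoms and 2 hydrogen-bond acceptors, enters where a single fluorine left, on the carbon para to a large group, and the read-out stays within the scatter. Set against the two chloro-bearing compounds, the same group gives a 1.5-fold higher number from compound 2 to compound 4 (0.19 log units; within the scatter) and a 1.4-fold higher number from compound 1 to compound 4 (0.15 log units; within the scatter) as the two largest steps on this ring among the four compounds, yet both also remain within the scatter, so this position has so far tolerated halogens and nitro alike in this assay. No supporting data bear on why the read-out responds so little to these exchanges.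

Still open, on these data alone, is whether an amine, a carboxylic acid or a longer chain such as butoxy at this same ring position would also stay within the scatter. Also open, as far as these compounds go, is whether changes elsewhere on the shared core, away from this aryl ring, would move the read-out any further than these exchanges have.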